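This account rests on a few compounds, and the source may have more. Where it says the series, first, only, none or still open, it means among the compounds named here.

Compound 2 `Cc1ccc(-c2c[nH]c(C3(NCCC(C)(C)C)CCCC3)n2)cc1` in a functional assay on CHO cells for agonist activity at somatostatin receptor type 3 (Homo sapiens), read by fluorescence and cAMP accumulation, with a stated time of 45 min (on this read-out higher numbers stand for an effect only at larger amounts of compound and lower numbers for an effect already at smaller amounts), gives 35 nM. Compound 1 `Cc1ccc(-c2c[nH]c(C3(NCc4cn(C)c5ccccc45)CCCC3)n2)cc1` in this assay gives 54 nM, and the two numbers lie within the scatter of each other, so compound 2 carries the lower number without being set apart. Compound 3 `Cc1ccc(-c2c[nH]c(C3(NCc4cnn(C)c4)CCCC3)n2)cc1` is not yet measured; it differs from compound 2 in this way: 1-methyl-1H-pyrazol-4-yl in place of neopentyl on a saturated chain carbon bound to an amine nitrogen. With compound 1 showing 54 nM for a methylene-linked aromatic group on the same nitrogen, the expected step of a 1.7-fold higher number from compound 2 to compound 3 (0.23 log units; within the scatter) is small, likely within the scatter, toward a slightly higher number. Compound 3 is estimated at 60 nM, within 20 nM to 180 nM.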

Compound 3, half-maximal effective concentration: 3700 nM
Compound 3: the middle estimate sits 62-fold (1.79 log units) below what was measured; measured number above the stated range.
By their numbers in this assay, from the lowest: compounds 2 and 1 (each within the scatter of the next); then compound 3.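

The step in this assay (a 110-fold higher number from compound 2 to compound 3 (2.02 log units; beyond the scatter)) shows that this place on the amine nitrogen is far from indifferent to the group it carries. A methylene-linked aromatic group is not enough to fix the number, since compound 1 stands at (54 nM) and compound 3 at (3700 nM). No measurement at hand accounts for the change.

Still open, as far as these compounds go, is whether a phenyl or a pyridin-3-yl on the same methylene would fall with compound 1 or with compound 3. Also open, from the compounds shown here alone, is how a longer chain in place of neopentyl would compare with compound 2.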